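Aryl for benzyl on the core of compound 2

The source may hold more compounds than are shown below. What is called first, only, known or untested is meant among the compounds shown, and "the series" means these compounds.

Measured compounds:
compound 1, `Nc1cccc(-c2cn3nc(-c4cccs4)sc3n2)c1`: > 250000 nM
compound 2, `C=C(Br)C(=O)Nc1cccc(-c2cn3nc(Cc4cccc(OC)c4)sc3n2)c1`: 2000 nM
compound 3, `COc1ccc(-c2nn3cc(-c4cccc(N)c4)nc3s2)cc1OC`: 16000 nM

In a functional assay on L1210 cells (Mus musculus) for inhibition, read by cell counting, with a stated time of 2 days (on this read-out lower numbers stand for stronger inhibition and higher numbers for weaker inhibition), compound 2 gives 2000 nM. That is the lowest of the two numbers shown, and the nearest number belongs to compound 3 with 16000 nM, a gap beyond the scatter. For compound 1 this assay gives only a limit, > 250000 nM; it is a limit and not a number. the limit of > 250000 nM in this assay, at which 1 of the 3 values shown sits.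

Compound 4, `C=C(Br)C(=O)Nc1cccc(-c2cn3nc(-c4cccc(OC)c4)sc3n2)c1`, is not yet measured in this assay. It differs from compound 2 in one place: 3-methoxyphenyl in place of 3-methoxybenzyl on an aromatic carbon. The bromoacrylamide on the aniline is kept, and the 3-methoxyphenyl enters where the 3-methoxybenzyl stood, on the aromatic carbon of the five-membered ring.

Among the measured compounds shown here, no measured pair shows the effect of such a change, so the expected step from compound 2 to compound 4 is small, and an estimate of a 1.5-fold higher number from compound 2 to compound 4 (0.18 log units; within the scatter) is taken as lying about within the scatter, with a slight lean toward a higher number. Compound 4 is therefore expected to give about 3000 nM in this assay, within a range of 800 nM to 12000 nM.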

Compound 4, half-maximal inhibitory concentration: 580 nM
Compound 4: the middle estimate sits 5.2-fold (0.71 log units) above what was measured, and the stated range ends above it.
By their numbers in this assay, from the lowest: compound 4; then compound 2; then compound 3. At a limit, above all of these: compound 1.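

In this assay, putting 3-methoxyphenyl in place of 3-methoxybenzyl on this aromatic carbon of the five-membered ring, with the bromoacrylamide kept, gives a 3.4-fold lower number from compound 2 to compound 4 (0.54 log units; beyond the scatter). This is the first pair shown that differs in one place, and it establishes that the read-out responds to a change at this position and that the 3-methoxybenzyl is not required for inhibition in these cells. Nothing measured here accounts for the size or direction of this step.

The two compounds of this pair leave open whether the gain belongs to the aryl ring itself or to the 3-methoxy group on it, since an unsubstituted phenyl does not appear among them. Also open, going by these compounds, is how this carbon would respond to a longer chain before the ring, or to a carboxylic acid or an amine on the ring in place of the methoxy group.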